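Oxazole in place of methylthiadiazole on the shared core

The source may hold more compounds than are shown below. What is called first, only, known or untested is meant among the compounds shown, and "the series" means these compounds.

Compound 1 `NC(=O)c1cnc(N2CCC(Oc3ccccc3C(F)(F)F)CC2)s1`: 3 nM
Compound 2 `NS(=O)(=O)c1cnc(N2CCC(Oc3ccccc3C(F)(F)F)CC2)s1`: 41 nM
Compound 3 `Cc1nnc(-c2cnc(N3CCC(Oc4ccccc4C(F)(F)F)CC3)s2)s1`: 750 nM

In an assay on microsomes from liver (strain Wistar) for inhibition of acyl-CoA desaturase 1 (Rattus norvegicus), read by HPLC, with stated times of 1 h and 60 min (on this read-out lower numbers stand for stronger inhibition and higher numbers for weaker inhibition), compound 3 gives the highest of the three numbers, with an 18-fold higher number from compound 2 to compound 3 (1.26 log units; beyond the scatter) and a 250-fold higher number from compound 1 to compound 3 (2.40 log units; beyond the scatter) both large. Compound 4 `FC(F)(F)c1ccccc1OC1CCN(c2ncc(-c3ncco3)s2)CC1` differs from compound 3 by 1,3-oxazol-2-yl in place of 5-methyl-1,3,4-thiadiazol-2-yl on an aromatic carbon. Among the measured compounds shown here, no measured step swaps one five-membered heteroaryl for another; the two steps that end at compound 3 only show that a five-membered aromatic ring in this place gives far higher numbers than carbamoyl or sulfamoyl. Because of a 250-fold higher number from compound 1 to compound 3 (2.40 log units; beyond the scatter) compound 4 is expected to stay far from compound 1. For compound 4 a step of a 1.5-fold lower number from compound 3 to compound 4 (0.18 log units; within the scatter) is estimated, not clearly beyond the scatter. Compound 4 is thus expected at 500 nM, between 120 nM and 2500 nM.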

Compound 4, half-maximal inhibitory concentration: 14 nM
Beside the measured number, compound 4's estimate is 36-fold (1.55 log units) above it; measured number below the stated range.
By their numbers in this assay, from the lowest: compound 1; then compound 4; then compound 2; then compound 3.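

In this assay, exchanging one five-membered aromatic ring for another produces a large change (a 54-fold lower number from compound 3 to compound 4 (1.73 log units; beyond the scatter)), so such a ring at this place does not in itself give high numbers. The 1,3-oxazol-2-yl group gives a lower number than sulfamoyl (a 2.9-fold lower number from compound 2 to compound 4 (0.47 log units; beyond the scatter)) but a higher one than carbamoyl (a 4.7-fold higher number from compound 1 to compound 4 (0.67 log units; beyond the scatter)). Nothing given here explains the difference between the two rings.

Going by these compounds, the step alters the methyl group, the ring sulfur and a ring nitrogen together, so which of these changes matters remains open. Also open, on these data alone, is what a 5-methyl-1,3-oxazol-2-yl group would give.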